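Varying the group on the amide-type nitrogen

The source may hold more compounds than are shown below. What is called first, only, known or untested is meant among the compounds shown, and "the series" means these compounds.

Compound 2 `COc1cc2c(Oc3ccc(NC(=O)Nc4ccc(OC(F)(F)F)cc4)cc3)ccnc2cc1OCCCCCCC(=O)NO` gives 3130 nM in a functional assay on A549 cells (Homo sapiens) for antiproliferative activity, read by MTT assay; a higher number here means a weaker inhibitor, a lower number a stronger inhibitor; of the three numbers measured it is the highest, although the gap to compound 1 `COc1cc2c(Oc3ccc(NC(=O)Nc4cccc(C)c4)cc3)ccnc2cc1OCCCCCCC(=O)NO`, at 2010 nM, is within the scatter, while compound 3 `COc1cc2c(Oc3ccc(NC(=O)Nc4ccccc4F)cc3)ccnc2cc1OCCCCCCC(=O)NO`, at 870 nM, sits furthest away. The step of a 1.6-fold higher number from compound 1 to compound 2 (0.19 log units; within the scatter) is within the scatter; a 3.6-fold lower number from compound 2 to compound 3 (0.56 log units; beyond the scatter) and a 2.3-fold lower number from compound 1 to compound 3 (0.36 log units; beyond the scatter) are modest. Compound 4 `COc1cc2c(Oc3ccc(NC(=O)N/N=C/c4ccc(F)cc4)cc3)ccnc2cc1OCCCCCCC(=O)NO` differs from compound 2 by a group of 9 heavy atoms (7 carbon, 1 nitrogen, 1 fluorine; one six-membered aromatic ring of carbon only) in place of a group of 11 heavy atoms (7 carbon, 1 oxygen, 3 fluorine; one six-membered aromatic ring of carbon only), on an amide-type nitrogen. The measured steps that bear on it all exchange the group on this same amide-type nitrogen and none exceeds a modest size, so a modest step, more likely downward than upward, is expected in this assay. Compound 4 is expected to give 1800 nM, with a range from 700 nM to 4500 nM. The step this estimate means is expected to be a 1.7-fold lower number from compound 2 to compound 4 (0.24 log units; within the scatter).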

Compound 4, half-maximal inhibitory concentration: 4920 nM
The estimate for compound 4 lay 2.7-fold (0.44 log units) below the measured number; measured number outside the range, above it.
By their numbers in this assay, from the lowest: compound 3; then compounds 1, 2 and 4 (each within the scatter of the next, the first and the last beyond it).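

In this assay, the step of a 1.6-fold higher number from compound 2 to compound 4 (0.20 log units; within the scatter) puts the new group level with 4-(trifluoromethoxy)phenyl on the amide-type nitrogen, while a 2.4-fold higher number from compound 1 to compound 4 (0.39 log units; beyond the scatter) and a 5.7-fold higher number from compound 3 to compound 4 (0.75 log units; beyond the scatter) are both modest losses. The last of these is the widest step yet at this position, so the range seen here now extends beyond that of the first three compounds. Nothing available explains the result. On these data alone, what remains open is how a 2-fluorophenyl would behave at the end of the new group, and how an amine or a carboxylic acid would behave on this nitrogen.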